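Five-membered heteroaryl swap and tolerated concentration in the cyclopentylamino series

The source may hold more compounds than are shown below. What is called first, only, known or untested is meant among the compounds shown, and "the series" means these compounds.

compound 1 `Fc1ccccc1-c1nc2ccccn2c1NC1CCCC1`: > 50000 nM
compound 2 `c1ccn2c(NC3CCCC3)c(-c3nccs3)nc2c1`: > 50000 nM

In an ADME assay on THP-1 cells (Homo sapiens) for cytotoxicity (a lower number here means that less compound is tolerated, a higher number that more compound is tolerated), compound 1 `Fc1ccccc1-c1nc2ccccn2c1NC1CCCC1` reaches only the assay limit, > 50000 nM. Compound 2 `c1ccn2c(NC3CCCC3)c(-c3nccs3)nc2c1` likewise stops at the limit, giving > 50000 nM. The step that the two limits leave unreadable from compound 1 to compound 2 therefore has no readable size, since both values sit at the limit of > 50000 nM in this assay, at which 2 of the 2 values shown sit. Compound 3 `Cn1ccnc1-c1nc2ccccn2c1NC1CCCC1` differs from compound 2 by 1-methyl-1H-imidazol-2-yl in place of 1,3-thiazol-2-yl on an aromatic carbon. Among the compounds with values here, the one measured step bears on this change but cannot be sized, so in this assay no step beyond the scatter is expected. Compound 3 is estimated at 60000 nM, range 20000 nM to 200000 nM, most likely again reported as a limit, which means an expected step that the limit leaves unreadable from compound 2 to compound 3.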

Compound 3, half-maximal cytotoxic concentration: > 50000 nM
Compound 3 ended at the assay's limit (the forecaster's own chance of this, stated with the estimate: 80%); the middle value does not contradict the limit.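

Within the data shown here, compound 3 joins compound 1 and compound 2 at the same limit, so no step among them can be read: the limit of > 50000 nM in this assay, at which 3 of the 3 values shown sit. Going by these compounds, how far any of the three compounds lies beyond that limit stays open.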